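The source may hold more compounds than are shown below. What is called first, only, known or untested is meant among the compounds shown, and "the series" means these compounds.

Measured compounds:

- compound 1, `N#C[Se]c1ccc(NC(=O)OCc2ccc([N+](=O)[O-])cc2)cc1`: 9300 nM
- compound 2, `C=CCOC(=O)Nc1ccc([Se]C#N)cc1`: 9200 nM
- compound 3, `CCCCOC(=O)Nc1ccc([Se][Se]c2ccc(NC(=O)OCCCC)cc2)cc1`: 16700 nM

All three were run in a functional assay on CCRF-CEM cells (Homo sapiens) for cytotoxicity, read by MTT assay, with a stated time of 72 h; a higher number here means a weaker inhibitor of growth, a lower number a stronger inhibitor of growth. In this assay compound 2 gives 9200 nM, the lowest of the three numbers, but the gap to compound 1 and the gap to compound 3 both lie within the scatter, so no order among the three can be read from these figures.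

Compound 4, `CCOC(=O)Nc1ccc([Se]C#N)cc1`, has not yet been measured in this assay. Against compound 2 it shows one change: methyl in place of vinyl on a saturated chain carbon bound to an oxygen next to a carbonyl group. Cut one bond further out, the same difference reads allyl to ethyl, or allyloxy to ethoxy. For the measured compounds named here, no pair of measured compounds that differ in only one place is available, so the size of this kind of step is not known from the data here.

The change is small and sits away from the part of the molecule that the three measured compounds share, and the three measured numbers themselves lie close together. The step from compound 2 to compound 4 is therefore expected to be small, a 1.0-fold lower number from compound 2 to compound 4 (0.01 log units; within the scatter), with no direction beyond the scatter. For compound 4 the estimated value in this assay is 9000 nM, with a range from 4500 nM to 18000 nM.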

Compound 4, concentration for 50% growth inhibition: 9800 nM
The estimate for compound 4 lay 1.1-fold (0.04 log units) below the measured number; low and high end bracket the measured number.
By their numbers in this assay, from the lowest: compounds 2, 1, 4 and 3 (each within the scatter of the next).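

In this assay, the series now has its first measured step in one place: methyl in place of vinyl on a saturated chain carbon bound to an oxygen next to a carbonyl group gives a 1.1-fold higher number from compound 2 to compound 4 (0.03 log units; within the scatter). For this pair, allyl and ethyl cannot be told apart at this position, so the double bond outside aromatic rings shows no measurable link to the read-out here. Nothing measured here bears on a reason for this result.

For the compounds shown here, this single step covers only two small carbon groups, and it does not show whether a longer chain, an amine or a carboxylic acid at this position would leave the number equally unmoved. It also leaves open whether the same change would give a similar step in another compound of the series.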